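Half-life after a cyano group joins compound 2

The compounds below may be only part of what the source reports. "The series", "measured", "known", "first", "only" and "open" are said of these compounds alone.

In an ADME assay on the whole organism for metabolic stability, with Rattus norvegicus as the target (on this read-out higher numbers stand for a longer-lived compound and lower numbers for a shorter-lived compound), compound 1 `O=C(Nc1cccnc1-c1ccsc1)N1CCN2C(=O)N([C@H]3C[C@@H]3c3ccccc3)C(=O)[C@@H]2C1` gives 10 h and compound 2 `O=C(Nc1cccnc1-c1ccccc1)N1CCN2C(=O)N([C@H]3C[C@@H]3c3ccccc3)C(=O)[C@@H]2C1` gives 4.9 h. For the measured compounds named here, compound 2 therefore holds the lower of the two numbers so far, with compound 1 as its nearest neighbour. Compound 3 `N#Cc1cccc(-c2ncccc2NC(=O)N2CCN3C(=O)N([C@H]4C[C@@H]4c4ccccc4)C(=O)[C@@H]3C2)c1` departs from compound 2 in one place, cyano in place of hydrogen on an aromatic carbon, turning phenyl into 3-cyanophenyl.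

Going by the values given here, only one measured step bears on this change. That step, a 2.0-fold lower number from compound 1 to compound 2 (0.31 log units; beyond the scatter), is modest and lies just beyond the scatter. It exchanges thiophen-3-yl for phenyl on an aromatic carbon, so it shows that this assay can respond to a change in this aromatic group. It does not involve cyano, however, and so gives no direction for the new change. No step beyond the scatter is therefore expected, and the estimate is a 1.0-fold higher number from compound 2 to compound 3 (0.01 log units; within the scatter). The uncertainty is wide enough to take in a step of the modest size already seen, in either direction. Compound 3 is expected at 5 h, with an estimated range from 2.5 h to 10 h.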

Compound 3, half-life: 3.8 h
Compound 3: middle estimate off by 1.3-fold (0.12 log units), on the high side; measured number inside the range.
By their numbers in this assay, from the lowest: compounds 3 and 2 (each within the scatter of the next); then compound 1.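

In this assay, for the compounds shown here, cyano on the six-membered aromatic ring of carbon only, meta to a large group, gives a 1.3-fold lower number from compound 2 to compound 3 (0.11 log units; within the scatter) and so does not separate 3-cyanophenyl from phenyl on this read-out, which is the first reading of a group added to this ring rather than an exchange of the ring itself. Set against thiophen-3-yl, 3-cyanophenyl gives a 2.6-fold lower number from compound 1 to compound 3 (0.42 log units; beyond the scatter) and thus stands apart from that group, as phenyl already did, so thiophen-3-yl remains the one aromatic group of the three that differs beyond the scatter from the other two. Nothing measured in this series accounts for either step.

As far as these compounds go, with a single group at one place on this ring, it remains open whether an amine, a carboxylic acid or a methoxy group there, or cyano elsewhere on the ring, would also leave the half-life within the scatter of compound 2. From the compounds shown here alone, it is also open whether cyano on the thiophene of compound 1 would leave the half-life of compound 1, 10 h, unchanged or bring it down.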